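This account rests on a few compounds, and the source may have more. Where it says the series, first, only, none or still open, it means among the compounds named here.

For the measured compounds named here, compound 2 `CCCN1CCN(c2ccc(S(=O)(=O)Oc3cccc(C)c3)cc2)C1=O` is the only compound here with a number in a functional assay on MCF7 cells (Homo sapiens) for antiproliferative activity, read by sulforhodamine B assay, with a stated time of 48 h (a higher number here means a weaker inhibitor, a lower number a stronger inhibitor), and that number, 86000 nM, marks a weak inhibitor. Compound 1 `CCN1CCN(c2ccc(S(=O)(=O)Oc3ccc(OC)cc3)cc2)C1=O` gives only a limit in this assay, > 100000 nM, so no number is known for it. Compound 3 `CCCN1CCN(c2ccc(S(=O)(=O)Oc3ccc(OC)cc3)cc2)C1=O` is not yet measured in this assay. The change from compound 2 to compound 3 is 4-methoxyphenyl in place of 3-methylphenyl on an oxygen. With compound 1 reaching only a limit, a step toward weaker inhibition or none beyond the scatter seems the likely outcome, so compound 3 is expected to give 110000 nM, somewhere between 50000 nM and 250000 nM, a step of a 1.3-fold higher number from compound 2 to compound 3 (0.11 log units; within the scatter).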

Compound 3, half-maximal inhibitory concentration: 20000 nM
The estimate for compound 3 lay 5.5-fold (0.74 log units) above the measured number; measured number outside the range, below it.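

In this assay, 4-methoxyphenyl in place of 3-methylphenyl on the oxygen bound to the sulfonyl sulfur gives a 4.3-fold lower number from compound 2 to compound 3 (0.63 log units; beyond the scatter), so the group at this position clearly matters. Compound 1 gives no number, only a limit of the assay: the limit of > 100000 nM in this assay, at which 1 of the 3 values shown sits. With 4-methoxyphenyl kept, methyl in place of hydrogen on a saturated chain carbon gives an at least 5.0-fold lower number from compound 1 to compound 3 (0.69 log units; beyond the scatter), so the chain matters too.

The swap changes both the group and where it sits on the phenyl ring, and the compounds shown do not separate the two. Going by these compounds, how an amine or carboxylic acid on that phenyl ring, or a longer chain, would behave stays open.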